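The compounds below may be only part of what the source reports. "The series", "measured", "known", "first", "only" and "open" are said of these compounds alone.

Of the compounds shown here, three that share one core have been tested in a functional assay on cells (Leukemia cell, Homo sapiens) for cytotoxicity, read by sulforhodamine B assay, with a stated time of 48 h; on this read-out higher numbers stand for weaker inhibition of growth and lower numbers for stronger inhibition of growth. Compound 1 `COc1ccc(OC)c(-c2cc(-c3ccc(Cl)cc3)nn2-c2ccc(S(=O)(=O)NC(C)=O)cc2)c1` gives 7450 nM, and compound 2 `NS(=O)(=O)c1ccc(-n2nc(-c3ccc(Cl)cc3)cc2-c2cc(O)ccc2O)cc1` gives 5030 nM. Compound 3 `CC(=O)NS(=O)(=O)c1ccc(-n2nc(-c3ccccc3)cc2-c2cc(O)ccc2O)cc1` gives 93600 nM, the highest of the three numbers; its gaps to compound 1 and to compound 2 both lie beyond the scatter, so compound 3 is the weakest growth inhibitor of the three that have been measured.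

Compound 4 `CC(=O)NS(=O)(=O)c1ccc(-n2nc(-c3ccc(Cl)cc3)cc2-c2cc(O)ccc2O)cc1` has not yet been measured. It differs from compound 3 in one place: chloro in place of hydrogen on an aromatic carbon. Within the data shown here, both compound 1 and compound 2 carry the 4-chlorophenyl group that compound 4 gains, and both give lower numbers than compound 3, but each also differs from compound 3 elsewhere, so no measured pair isolates this change by itself. The change is nevertheless expected to lower the number, toward stronger growth inhibition, by about a 9.4-fold lower number from compound 3 to compound 4 (0.97 log units; beyond the scatter). For compound 4 the estimate in this assay is 10000 nM, with a likely range from 3000 nM to 35000 nM.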

Compound 4, concentration for 50% growth inhibition: 37400 nM
Beside the measured number, compound 4's estimate is 3.7-fold (0.57 log units) below it, outside the stated range (above it).
By their numbers in this assay, from the lowest: compounds 2 and 1 (each within the scatter of the next); then compound 4; then compound 3.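

With all else held fixed, going from phenyl to 4-chlorophenyl gives a 2.5-fold lower number from compound 3 to compound 4 (0.40 log units; beyond the scatter) in this assay and so isolates a real but modest gain in growth inhibition at this position. Compound 4 also opens direct comparisons at two other places: acetyl in place of hydrogen on the sulfonamide nitrogen gives a 7.4-fold higher number from compound 2 to compound 4 (0.87 log units; beyond the scatter) and 2,5-dihydroxyphenyl in place of 2,5-dimethoxyphenyl gives a 5.0-fold higher number from compound 1 to compound 4 (0.70 log units; beyond the scatter) in the same assay. The chloro group alone therefore does not account for the low numbers of compound 1 and compound 2, since compound 4 carries it too and still gives a higher number than either.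

From the compounds shown here alone, whether a bromo or a methoxy group at this position would lower the number further remains open. Nothing available here explains why any of these changes has the size it does.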